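Two weak compounds and a swap on the amine nitrogen

The compounds below may be only part of what the source reports. "The series", "measured", "known", "first", "only" and "open" are said of these compounds alone.

Compound 1 `Cc1cccc(Nc2nc(C)c(C(=O)/C=C/c3ccccc3Cl)s2)c1` and compound 2 `COc1cc(/C=C/C(=O)c2sc(Nc3ccc(Cl)c(Cl)c3)nc2C)cc(OC)c1OC` share a core. In a functional assay on BGC-823 cells (Homo sapiens) for cytotoxicity, read by MTT assay (on this read-out higher numbers stand for weaker inhibition and lower numbers for stronger inhibition), compound 1 gives 24200 nM. Compound 2 reaches only the limit of the measurement, > 25000 nM, so no number is known for it; it sits at the limit of > 25000 nM in this assay, at which 1 of the 2 values shown sits. Compound 3 `COc1cc(/C=C/C(=O)c2sc(Nc3cccc(C)c3)nc2C)cc(OC)c1OC` differs from compound 2 in one place: 3-methylphenyl in place of 3,4-dichlorophenyl on a nitrogen on an aromatic ring. Among the compounds with values here, no measured pair differs in only this place, so no step has been observed. Compound 1 carries the same 3-methylphenyl group and gives 24200 nM, so no step beyond the scatter is expected. Compound 3 is therefore estimated at 25000 nM, between 10000 nM and 60000 nM. The expected step is a number no higher from compound 2 to compound 3 (the limit leaves the size open).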

Compound 3, half-maximal inhibitory concentration: 17200 nM
For compound 3 the middle estimate is 1.5-fold (0.16 log units) above the measured one; measured number inside the range.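

Placing 3-methylphenyl on the nitrogen in place of 3,4-dichlorophenyl gives an at least 1.4-fold lower number from compound 2 to compound 3 (0.16 log units; that floor lies within the scatter). This change therefore brings the compound within the measurable range of the assay, although the smallest step the data allow is no larger than ordinary variation between repeats. The true size of the step stays unknown because compound 2 has only a limit and not a number: the limit of > 25000 nM in this assay, at which 1 of the 3 values shown sits.

The compounds shown leave open how this position would respond to a phenyl ring carrying a carboxylic acid or an amine. They also leave open whether any group here could give a much lower number.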